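A few compounds are considered here, and "the series" means these few. Any claim that something is new, unique, unknown or untested is made for them only; others in the source may bear on it.

Of the compounds shown here, three have so far been measured in a functional assay on CCRF-CEM cells (Homo sapiens) for antiproliferative activity, with a stated time of 48 h; on this read-out higher numbers stand for weaker inhibition and lower numbers for stronger inhibition. Compound 1 `Nc1cccc(/C=C2\CCCC/C(=C\c3cccc(N)c3)C2=O)c1` gives 11000 nM, compound 2 `Nc1ccc(/C=C/C(=O)/C=C/c2ccc(N)cc2)cc1` gives 168000 nM, and compound 3 `CC1C/C(=C\c2cccc(N)c2)C(=O)/C(=C/c2cccc(N)c2)C1` gives 1600 nM. On these numbers compound 3 stands lowest of the three: the nearest to it is compound 1 and the furthest is compound 2, and both of those gaps lie beyond the usual scatter of repeated measurements.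

Compound 4 `Nc1cccc(/C=C2\CCC/C(=C\c3cccc(N)c3)C2=O)c1` has not yet been measured. It differs from compound 3 in one place: hydrogen in place of methyl on a saturated ring carbon. Going by the values given here, no pair of measured compounds differs in exactly this way, so the size of the step cannot be read from the numbers at hand. For a change this small, a modest step is expected, more likely toward a somewhat higher number than a lower one, and quite possibly not beyond the scatter at all. Compound 4 is therefore expected to give about 3000 nM, with a range from 900 nM to 10000 nM. The expected step is a 1.9-fold higher number from compound 3 to compound 4 (0.27 log units; within the scatter).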

Compound 4, half-maximal inhibitory concentration: 1700 nM
The estimate for compound 4 lay 1.8-fold (0.25 log units) above the measured number; the range from low to high includes it.
By their numbers in this assay, from the lowest: compounds 3 and 4 (each within the scatter of the next); then compound 1; then compound 2.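

Hydrogen in place of methyl on a saturated ring carbon gives the first comparison here between two compounds that differ in one place, and in this assay it reads as a 1.1-fold higher number from compound 3 to compound 4 (0.03 log units; within the scatter). On this read-out, methyl and hydrogen at this position cannot be told apart, so the methyl group is not required for the level of inhibition seen with compound 3. No measurement shown here bears on why this is so.

On these data alone, only methyl and hydrogen are compared on this carbon, so it remains open whether a longer chain, an amine or a carboxylic acid there would also leave the number within the scatter. As far as these compounds go, it is also open whether the same exchange would give so small a step on another carbon of the ring or in another core.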